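Aryl swap on the carbinol core: clearance outlook

The compounds below may be only part of what the source reports. "The series", "measured", "known", "first", "only" and "open" are said of these compounds alone.

Among the compounds with values here, compound 2 `Nc1ccc(S(=O)(=O)N2CCN(c3ncc(C(O)(C(F)(F)F)C(F)(F)F)cc3-c3cccc(F)c3)CC2)cn1` gives 52 mL.min-1.g-1 in an ADME assay (liver) for metabolic stability, with Liver microsome (Rattus norvegicus) as the target, using microsomes and NADPH, with a stated time of 30 min, tested at 1 uM; on this read-out lower numbers stand for slow clearance and higher numbers for fast clearance; this is the only plain number so far in this read-out. Compound 1 `COc1cc(C(O)(C(F)(F)F)C(F)(F)F)cnc1N1CCN(S(=O)(=O)c2ccc(N)nc2)CC1` is reported in this assay as < 14 mL.min-1.g-1, which is a limit of the measurement and not a number (the limit of < 14 mL.min-1.g-1 in this assay, at which 1 of the 2 values shown sits). Within the data shown here, the single measured step, an at least 3.7-fold higher number from compound 1 to compound 2 (0.56 log units; beyond the scatter), concerns a methoxy-to-aryl exchange and so does not directly cover a change inside the aryl group itself. Compound 3 `Nc1ccc(S(=O)(=O)N2CCN(c3ncc(C(O)(C(F)(F)F)C(F)(F)F)cc3-c3cnccc3F)CC2)cn1` differs from compound 2 by 4-fluoropyridin-3-yl in place of 3-fluorophenyl on an aromatic carbon. With no measured step of this kind in the series, the expectation is a step that stays close to the scatter, leaning towards a somewhat lower number. Compound 3 is therefore estimated at 30 mL.min-1.g-1 in this assay, with a range from 12 mL.min-1.g-1 to 70 mL.min-1.g-1. The implied step, a 1.7-fold lower number from compound 2 to compound 3 (0.24 log units; within the scatter), is expected to be modest at most.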

Compound 3, intrinsic clearance in microsomes: 22 mL.min-1.g-1
Compound 3: the middle estimate sits 1.4-fold (0.13 log units) above what was measured; the measured number falls inside the stated range.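

In this assay, the identity of the aryl group at this position matters, not only the exchange of methoxy for an aryl group: the change to 4-fluoropyridin-3-yl, which brings one hetero atom into the ring, gives a 2.4-fold lower number from compound 2 to compound 3 (0.37 log units; beyond the scatter). Compound 1 remains a limit of the measurement and not a number: the limit of < 14 mL.min-1.g-1 in this assay, at which 1 of the 3 values shown sits. Against that limit, the reading is an at least 1.5-fold higher number from compound 1 to compound 3 (0.19 log units; that floor lies within the scatter), so a real rise over methoxy is not established for 4-fluoropyridin-3-yl.

On these data alone, whether the ring nitrogen alone carries the drop from 3-fluorophenyl stays open; the two groups also differ in where the fluorine sits. Also open, as far as these compounds go, is how an unsubstituted pyridin-3-yl, or an aryl group bearing an amine or a carboxylic acid, would read in this assay.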